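Ethynyl for Phenyl in a Quinolinone Carboxamide Series

The source may report more compounds than this note shows. Statements on the series, on what has been measured and on what is new or still open speak of the compounds shown alone.

Compound 1 `O=C(Nc1cc(F)c(F)c(F)c1)c1cc(=O)[nH]c2cc(Br)ccc12` carries a bromine on the shared core. In a functional assay on KYSE-70 cells for antiproliferative activity against KYSE-70 cell line (Homo sapiens), read by MTT assay, with a stated time of 72 h (on this read-out higher numbers stand for weaker inhibition and lower numbers for stronger inhibition), compound 1 reaches only the limit of the assay, > 20000 nM. Compound 2 `O=C(Nc1cccc(F)c1)c1cc(=O)[nH]c2cc(-c3ccccc3)ccc12` carries a phenyl in its place. In this assay compound 2 likewise reaches only the limit, > 20000 nM. Compound 2 therefore stands at the limit of > 20000 nM in this assay, at which 2 of the 2 values shown sit, and no numerical gap between the two measured compounds can be given.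

Compound 3 `C#Cc1ccc2c(C(=O)Nc3cccc(F)c3)cc(=O)[nH]c2c1` differs from compound 2 by ethynyl in place of phenyl on an aromatic carbon. Among the compounds with values here, since neither measured compound gave a number, no step between them is known and no direction can be drawn from the data. The step expected for compound 3 is a step that the limit leaves unreadable from compound 2 to compound 3, which is not beyond the usual scatter. Compound 3 is estimated at 25000 nM, with a range from 5000 nM to 100000 nM, and a limit is the most probable outcome.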

Compound 3, half-maximal inhibitory concentration: 9500 nM
Beside the measured number, compound 3's estimate is 2.6-fold (0.42 log units) above it; low and high end bracket the measured number.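

Ethynyl in place of phenyl on an aromatic carbon gives an at least 2.1-fold lower number from compound 2 to compound 3 (0.32 log units; beyond the scatter) in this assay. This shows that the group at this position can move the read-out on the shared core, and that the smaller ethynyl, with no ring, is tolerated here, as compound 3 gives 9500 nM. The true size of the step stays unknown because the value of compound 2 is a limit and not a number: the limit of > 20000 nM in this assay, at which 2 of the 3 values shown sit.

The compounds shown do not separate the loss of the phenyl ring from the entry of the triple bond as the source of the change. From the compounds shown here alone, whether a nitrile, an amine or a longer chain ending in a triple bond on this aromatic carbon would lower the number further also remains open.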